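The compounds below may be only part of what the source reports. "The series", "measured", "known", "first", "only" and "open" are said of these compounds alone.

The measured compounds:
- compound 1 `Nc1cc(N)c2nc(-c3ccccc3)c(Oc3ccc(Cl)c(Cl)c3)nc2c1` gives in a functional assay on RXF 393 cells (Homo sapiens) for inhibition, read by sulforhodamine B assay, with a stated time of 48 h (a lower number here means that less compound is tolerated, a higher number that more compound is tolerated), a limit of < 100000 nM, not a number.
- compound 2 `COc1cc(CNc2nc3cc(N)cc(N)c3nc2-c2ccccc2)cc(OC)c1OC` gives in this assay a limit of < 50200 nM, not a number.
- compound 3 `CCOC(=O)[C@H](CCC(=O)O)NC(=O)c1ccc(Oc2nc3cc(N)cc(N)c3nc2-c2ccccc2)cc1` gives in this assay a limit of < 50200 nM, not a number.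

None of the three compounds has a measured number in this assay, so nothing can be said about how they order against each other. Compound 1 stands at the limit of < 100000 nM in this assay, at which 1 of the 3 values shown sits, the less telling of the two limits. On these data alone, compounds 2 and 3 sit at the limit of < 50200 nM in this assay, at which 2 of the 3 values shown sit, which only shows that both are tolerated up to a lower ceiling than compound 1 was tested to; whether they actually differ from compound 1 is unknown.

Compound 4 `Nc1cc(N)c2nc(-c3ccccc3)c(NCc3ccc(F)cc3)nc2c1` differs from compound 1 in a single place: (4-fluorobenzyl)amino in place of 3,4-dichlorophenoxy on an aromatic carbon. The shared core of compound 1 is kept; the change is (4-fluorobenzyl)amino in place of 3,4-dichlorophenoxy on an aromatic carbon. Among the measured compounds shown here, with no step between measured compounds to lean on, the size and direction of the change cannot be read from the data. The step from compound 1 to compound 4 is expected to be a step that the limit leaves unreadable from compound 1 to compound 4, with wide uncertainty. Compound 4 is expected to give about 30000 nM in this assay, somewhere between 5000 nM and 100000 nM.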

Compound 4, concentration lethal to 50% of the cells: 60300 nM
Beside the measured number, compound 4's estimate is 2.0-fold (0.30 log units) below it; the measured number falls inside the stated range.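

In this assay compound 1 gives < 100000 nM, which is a limit and not a number. Among the compounds shown here, compound 4 therefore yields no step from compound 1 that can be read, in size or direction. Left open is how compound 1, compound 2 and compound 3, all known here only through limits, rank against compound 4 and each other.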